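The source may report more compounds than this note shows. Statements on the series, on what has been measured and on what is new or still open speak of the compounds shown alone.

In a physicochemical assay for lipophilicity (a lower number here means a more polar compound, a higher number a more lipophilic compound), compound 1 `C=C(c1cccc2ccccc12)C1CCC2(CC1)COC(Nc1ccc(F)cc1)OO2` gives 5.75, compound 2 `C=C(c1cccc2ccccc12)C1CCC2(CC1)COC(Nc1ccccc1-c1ccccc1)OO2` gives 7.26 and compound 3 `C=C(c1cccc2ccccc12)C1CCC2(CC1)COC(Nc1cccc(C(F)(F)F)c1)OO2` gives 6.51. Compound 3 is thus the second highest of the three. Compound 4 `C=C(c1cccc2ccccc12)C1CCC2(CC1)COC(Nc1ccc(C(F)(F)F)cc1)OO2` differs from it in one place: 4-(trifluoromethyl)phenyl in place of 3-(trifluoromethyl)phenyl on an amine nitrogen, with 4-(trifluoromethyl)phenyl in place of 3-(trifluoromethyl)phenyl on an amine nitrogen. Among the measured compounds shown here, two measured steps bear on this change: a number 0.76 log units higher from compound 1 to compound 3 (beyond the scatter) and a number 0.75 log units lower from compound 2 to compound 3 (beyond the scatter). For the measured compounds named here, both exchange one group for a different one, whereas here the same atoms are only joined differently, and no measured step shows such a swap. No step beyond the scatter is therefore expected in this assay. The expected step is a number 0.01 log units lower from compound 3 to compound 4 (within the scatter). For compound 4 the estimated value is 6.5, with a range from 6.1 to 6.9.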

Compound 4, partition coefficient: 6.51
Compound 4: the middle estimate sits 0.01 log units below what was measured; measured number inside the range.
By their numbers in this assay, from the lowest: compound 1; then compounds 3 and 4 (each within the scatter of the next); then compound 2.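

In this assay the exchange of 3-(trifluoromethyl)phenyl for 4-(trifluoromethyl)phenyl on the amine nitrogen gives no change at the digits printed from compound 3 to compound 4 (within the scatter) and is the only step shown in which the same atoms are merely joined differently. The other two steps, a number 0.76 log units higher from compound 1 to compound 4 (beyond the scatter) and a number 0.75 log units lower from compound 2 to compound 4 (beyond the scatter), leave compound 4 standing as compound 3 does against these two compounds. No evidence is available to explain this result. On these data alone, whether other groups on this phenyl ring, such as a nitrile or a carboxylic acid, would behave alike stays open.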